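The source may hold more compounds than are shown below. What is called first, only, known or untested is meant among the compounds shown, and "the series" means these compounds.

Compound 1 `CNC(=O)c1ccc([C@H](C(=O)NC(C)C)N2C(=O)[C@@H](C3Cc4ccccc4C3)NC(=O)[C@H]2CC(C)C)o1` is the reference point here. In an assay on isolated protein for binding affinity to Oxytocin receptor (Homo sapiens) (a higher number here means a weaker inhibitor, a lower number a stronger inhibitor), compound 1 gives 39.8 nM, the highest number of the three measured. Compound 2 `CC(C)C[C@@H]1C(=O)N[C@H](C2Cc3ccccc3C2)C(=O)N1[C@@H](C(=O)NC(C)C)c1ccc(Br)o1` gives 0.794 nM in this assay, and compound 3 `CC(C)C[C@@H]1C(=O)N[C@H](C2Cc3ccccc3C2)C(=O)N1[C@@H](C(=O)NC(C)C)c1ccc(Br)s1` gives 2 nM. The step of a 50-fold lower number from compound 1 to compound 2 (1.70 log units; beyond the scatter) and the step of a 20-fold lower number from compound 1 to compound 3 (1.30 log units; beyond the scatter) are both large, while the step of a 2.5-fold higher number from compound 2 to compound 3 (0.40 log units; beyond the scatter) is modest.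

Compound 4 `CC(C)C[C@@H]1C(=O)N[C@H](C2Cc3ccccc3C2)C(=O)N1[C@@H](C(=O)NC(C)C)c1cc(Br)cs1` has not been measured. Its change from compound 1 is a group of 6 heavy atoms (4 carbon, 1 sulfur, 1 bromine; one five-membered aromatic ring with 1 hetero atom) in place of a group of 9 heavy atoms (6 carbon, 1 nitrogen, 2 oxygen; one five-membered aromatic ring with 1 hetero atom), on a saturated chain carbon bound to an amide-type nitrogen in a ring and a carbonyl carbon. The measured step that bears most directly on it is a 20-fold lower number from compound 1 to compound 3 (1.30 log units; beyond the scatter), where the entering group shares the same atom count and the same ring type with the 4-bromothiophen-2-yl group and differs from it only in the name of the entering group. The step of a 50-fold lower number from compound 1 to compound 2 (1.70 log units; beyond the scatter) points the same way, so a large drop in number is expected for compound 4, roughly a 13-fold lower number from compound 1 to compound 4 (1.12 log units; beyond the scatter). Compound 4 is therefore estimated at 3 nM, within a range of 0.8 nM to 12 nM.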

Compound 4, inhibition constant: 1 nM
Beside the measured number, compound 4's estimate is 3.0-fold (0.48 log units) above it; low and high end bracket the measured number.
By their numbers in this assay, from the lowest: compounds 2, 4 and 3 (each within the scatter of the next, the first and the last beyond it); then compound 1.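

In this assay, the 4-bromothiophen-2-yl group keeps the large gain over the methylcarbamoyl-bearing furan at this saturated chain carbon (a 40-fold lower number from compound 1 to compound 4 (1.60 log units; beyond the scatter)), so that gain is not tied to the 5-bromo arrangement of compound 2 and compound 3. The bromine arrangement on the thiophene is not resolved here (a 2.0-fold lower number from compound 3 to compound 4 (0.30 log units; within the scatter)), and compound 4 also stands within the scatter of the bromofuran compound 2 (a 1.3-fold higher number from compound 2 to compound 4 (0.10 log units; within the scatter)), which suggests some tolerance for this change among the three bromo compounds. No measurement bears on why these numbers fall as they do.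

The compounds shown leave open how much of the gain belongs to the bromine itself and how much to the loss of the methylcarbamoyl group. A chloro or methyl group in the bromine's place, or a thiophene carrying no bromine at all, would separate the two.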